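The compounds below may be only part of what the source reports. "The series", "measured", "known", "first", "only" and "open" are said of these compounds alone.

Measured in an assay on HEK293 cells for inhibition of Steryl-sulfatase (Homo sapiens), tested at 0.1 uM; a lower number here means a weaker effect, a higher number a stronger effect of the compound at the concentration tested:
- compound 1 `CN(C)CCN(CCN(C)C)c1cccc(C(=O)N2CCc3ccc(OS(N)(=O)=O)cc3C2)c1`: 0%
- compound 2 `CN(C)CCN(CCN(C)C)c1ccc(C(=O)N2CCc3ccc(OS(N)(=O)=O)cc3C2)cc1`: 3.8%
- compound 3 `NS(=O)(=O)Oc1ccc2c(c1)CN(C(=O)c1cccc(N(Cc3ccccc3)Cc3ccco3)c1)CC2`: 27.5%

Compound 1 gives the lowest of the three numbers in this assay; compound 2 lies within the usual scatter of it, whereas compound 3 sits beyond the scatter above it. Compound 4 `NS(=O)(=O)Oc1ccc2c(c1)CN(C(=O)c1cccc(N3CCc4ccccc4C3)c1)CC2` comes from compound 1 through a single change: 1,2,3,4-tetrahydroisoquinolin-2-yl in place of bis(2-(dimethylamino)ethyl)amino on an aromatic carbon. For the measured compounds named here, no measured pair shows exactly this exchange, so its size is not known from the data. Going by the values given here, the only related observation is compound 3, whose amine also carries rings and which gives 27.5%. A moderate rise is therefore expected, a number 18 percentage points higher from compound 1 to compound 4 (beyond the scatter), with a wide range. Compound 4 is estimated at 18%, between 0% and 40%.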

Compound 4, a percentage reported as inhibition, at one concentration (the size of the read-out at that concentration, not a potency): 24.1%
Beside the measured number, compound 4's estimate is 6.1 percentage points below it; the measured number falls inside the stated range.
By their numbers in this assay, from the lowest: compounds 1 and 2 (each within the scatter of the next); then compounds 4 and 3 (each within the scatter of the next).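

In this assay, for the compounds shown here, the exchange of bis(2-(dimethylamino)ethyl)amino for 1,2,3,4-tetrahydroisoquinolin-2-yl on this aromatic carbon gives a number 24.1 percentage points higher from compound 1 to compound 4 (beyond the scatter) and is the first single-place step available here. It shows that the read-out at this position depends on the group attached there. No available evidence accounts for the rise.

The compounds shown leave open whether the gain comes from the added rings or from the loss of the dimethylamino chains. A piperidine or a single 2-(dimethylamino)ethyl chain on the same carbon would help separate the two.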